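The source may hold more compounds than are shown below. What is called first, only, known or untested is meant among the compounds shown, and "the series" means these compounds.

In a functional assay on HeLa cells (Homo sapiens) for antiproliferative activity, read by cell counting, with a stated time of 2 days (on this read-out lower numbers stand for stronger inhibition and higher numbers for weaker inhibition), compound 1 (`COc1ccc(Nc2nc(N)c(C(=O)c3ccc(Br)cc3)s2)cc1`) gives 79 nM as the lower of two numbers, and compound 2 (`COc1ccc(Nc2nc(N)c(C(=O)c3ccc([N+](=O)[O-])cc3)s2)cc1`) gives 350 nM as the higher. Compound 3 (`COc1ccc(Nc2nc(N)c(C(=O)c3cccc(OC)c3)s2)cc1`) carries 3-methoxyphenyl in place of 4-bromophenyl on a carbonyl carbon. Among the compounds with values here, the one measured step (a 4.4-fold higher number from compound 1 to compound 2 (0.65 log units; beyond the scatter)) puts nitro in place of bromo on an aromatic carbon and is modest. Within the data shown here, no measured compound carries methoxy, so that step is only a rough guide. A modest step to a higher number is expected in this assay (a 3.2-fold higher number from compound 1 to compound 3 (0.50 log units; beyond the scatter)). The expected value for compound 3 is 250 nM with 70 nM to 1000 nM as the estimated range.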

Compound 3, half-maximal inhibitory concentration: 37 nM
For compound 3 the middle estimate is 6.8-fold (0.83 log units) above the measured one; measured number below the stated range.
By their numbers in this assay, from the lowest: compound 3; then compound 1; then compound 2.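

In this assay, 3-methoxyphenyl in place of 4-bromophenyl on the carbonyl carbon gives a 2.1-fold lower number from compound 1 to compound 3 (0.33 log units; beyond the scatter) and so brings the series to its lowest number. Bromine is therefore not required at this place, and a methoxy-bearing ring is accepted. The step changes both the substituent and its ring numbering, and no available evidence bears on the reason for the shift.

Whether the methoxy group or its ring location accounts for the step stays open, as 4-methoxyphenyl and 3-bromophenyl would separate the two. As far as these compounds go, how an amine or a carboxylic acid on this ring would read also remains open.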